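Cyclohexyl for isopropyl: a change tested at two places

The compounds below may be only part of what the source reports. "The series", "measured", "known", "first", "only" and "open" are said of these compounds alone.

Of the compounds shown here, three in this set have been measured in an assay for inhibition of cathepsin S (Homo sapiens); on this read-out higher numbers stand for weaker inhibition and lower numbers for stronger inhibition. Compound 1, `CC(C)C[C@H](NC(=O)N1CCOCC1)C(=O)NC(C)(C)C#N`, gives 114 nM in this assay. Compound 2, `CC(C)[C@H](NC(=O)N1CCOCC1)C(=O)N[C@H](C#N)CCc1ccccc1`, gives 6000 nM, and compound 3, `N#C[C@H](CCc1ccccc1)NC(=O)[C@@H](NC(=O)N1CCOCC1)C1CCCCC1`, gives 84 nM. Compound 1 and compound 2 share little enough that the difference between the two cores is not broken down here.

Compound 2 and compound 3 differ in one place: cyclohexyl in place of isopropyl on a saturated chain carbon bound to an amide-type nitrogen and a carbonyl carbon. This single exchange made the step of a 71-fold lower number from compound 2 to compound 3 (1.85 log units; beyond the scatter), by far the largest movement among the measured compounds.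

Compound 4, `CC(C)(C#N)NC(=O)[C@H](CC1CCCCC1)NC(=O)N1CCOCC1`, has not yet been measured. It differs from compound 1 in what is the same kind of change: cyclohexyl in place of isopropyl on a saturated chain carbon, two bonds along the chain from an amide-type nitrogen and a carbonyl carbon. The group that leaves and the group that enters are the same as between compound 2 and compound 3, but the place is not: there the carbon carrying the group is bound directly to the amide-type nitrogen and the carbonyl carbon, here it sits two bonds along the chain from them.

Within the data shown here, because compound 1 already stands at 114 nM, the step from compound 1 to compound 4 is expected to be smaller than the one seen from compound 2 to compound 3, and the estimate is a 2.3-fold lower number from compound 1 to compound 4 (0.36 log units; beyond the scatter). Compound 4 is accordingly expected to give about 50 nM in this assay, with a plausible range from 10 nM to 300 nM.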

Compound 4, half-maximal inhibitory concentration: 17 nM
Beside the measured number, compound 4's estimate is 2.9-fold (0.47 log units) above it; measured number inside the range.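

In this assay, cyclohexyl in place of isopropyl lowered the number on the second core as well, giving a 6.7-fold lower number from compound 1 to compound 4 (0.83 log units; beyond the scatter), which means the direction of the change carried over in both pairs available here. The size of the step did not carry over, and the gap between the two steps is larger than repeat measurements alone would be expected to produce: the same change on two cores in this assay, a 71-fold lower number (1.85 log units; beyond the scatter) from compound 2 to compound 3 and a 6.7-fold lower number (0.83 log units; beyond the scatter) from compound 1 to compound 4, 11-fold (1.03 log units) apart, beyond the scatter of two such steps These two pairs do not show why the steps differ, since the group sits at a different place in each pair and the rest of the core differs too; the numbers cannot separate those two differences, and they give no reliable size for the step on a third core.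

On these data alone, it remains open whether a smaller ring such as cyclopentyl, a flat ring such as phenyl, or a branched group such as tert-butyl on that same saturated chain carbon would follow cyclohexyl or behave differently. It also remains open how far the lower number of compound 4 is specific to cathepsin S, as no other enzyme appears among the results shown.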